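The source may hold more compounds than are shown below. What is called first, only, known or untested is meant among the compounds shown, and "the series" means these compounds.

Measured compounds:
Compound 1, `Cn1c(Cc2nn(C)c(=O)c3ccccc23)nnc1SCCCCCCCC(=O)Nc1ccc(Cl)cc1Cl` — in an assay on 32D cells for inhibition of interleukin-15 (Mus musculus), read by resazurin assay, with stated times of 30 min and 2.5 days, in the presence of a further agent that is not named here (a higher number here means a weaker inhibitor, a lower number a stronger inhibitor), compound 1 gives 3900 nM.
Compound 2, `Cn1c(Cc2nn(CCC(=O)O)c(=O)c3ccccc23)nnc1SCCCCCCCC(=O)Nc1ccc(Cl)cc1Cl` — in this assay compound 2 gives only a limit, > 30000 nM.

Compound 2 thus stands at the weak end of the two numbers: its value in this assay is a limit of the assay and not a number, as described in the limit of > 30000 nM in this assay, at which 1 of the 2 values shown sits. Within the data shown here, the one measured step that bears on it, an at least 7.6-fold higher number from compound 1 to compound 2 (0.88 log units; beyond the scatter), went in the weaker direction when the acid-bearing chain was introduced on the ring nitrogen.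

The unmeasured compound 3, `Cn1c(Cc2n[nH]c(=O)c3ccccc23)nnc1SCCCCCCCC(=O)Nc1ccc(Cl)cc1Cl`, reverses that theme. The change from compound 2 to compound 3 is hydrogen in place of 2-carboxyethyl on an aromatic nitrogen; in words, hydrogen in place of 2-carboxyethyl on an aromatic nitrogen. Since the carboxyl-bearing substituent is what separated compound 2 from compound 1, its removal is expected to restore the number to a range near that of compound 1. The step of an at least 7.5-fold lower number from compound 2 to compound 3 (0.87 log units; beyond the scatter) is therefore expected to be a clear recovery in this assay. Compound 3 is estimated at 4000 nM, with a range from 1500 nM to 15000 nM.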

Compound 3, half-maximal inhibitory concentration: > 30000 nM
Compound 3: only a limit was reported (the forecaster's own chance of this, stated with the estimate: 10%); middle value at least 7.5-fold (0.87 log units) from the limit.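

Hydrogen in place of methyl on the aromatic nitrogen gives an at least 7.6-fold higher number from compound 1 to compound 3 (0.88 log units; beyond the scatter) in this assay, so a weaker number at this position is not tied to the carboxylic acid of compound 2. Compound 2 and compound 3, carrying 2-carboxyethyl and hydrogen on this nitrogen, both end at a limit of the assay, so the step between them cannot be read and the two cannot be ranked against each other. Among the three compounds, the methyl of compound 1 is thus the only substituent at this nitrogen that gives a readable number, and how far the other two lie past it stays unknown, as the record shows: the limit of > 30000 nM in this assay, at which 2 of the 3 values shown sit.

The compounds shown leave open whether the number of compound 1 depends on that single methyl group, or whether an ethyl group or a plain propyl chain on the same nitrogen would hold or improve it. They also leave open whether a chain ending in a methyl ester or a primary amide would behave like the 2-carboxyethyl group of compound 2.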